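A few compounds are considered here, and "the series" means these few. Any claim that something is new, unique, unknown or untested is made for them only; others in the source may bear on it.

Measured so far in a functional assay on Malme-3M cells (Homo sapiens) for inhibition, read by sulforhodamine B assay, with a stated time of 48 h; on this read-out higher numbers stand for weaker inhibition of growth and lower numbers for stronger inhibition of growth:
- compound 1 `COc1cc(C)cc(-c2c(-c3ccnc(-c4ccc(C(C)=O)cc4)c3)cnn2CC#N)c1`: > 100000 nM, a limit of the assay and not a number
- compound 2 `COc1cc(C)cc(-c2nn(CC#N)cc2-c2ccc(-c3cccc(C(C)=O)c3)nc2)c1`: 96400 nM
- compound 3 `Cc1cc(O)cc(-c2nn(CC#N)cc2-c2ccnc(-c3ccc(Oc4ccccc4)cc3)c2)c1`: 3580 nM

Of the two numbers, compound 3 holds the lower one; compound 2 stands higher by a gap beyond the scatter. Compound 1 sits at the limit of > 100000 nM in this assay, at which 1 of the 3 values shown sits, and yields no number.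

Compound 4 `Cc1cc(O)cc(-c2nn(CC#N)cc2-c2ccnc(-c3ccc(N(C)C)cc3)c2)c1` keeps the whole of compound 3 except for one change: dimethylamino in place of phenoxy on an aromatic carbon. Within the data shown here, no measured pair in this set shows this kind of exchange, so there is no step to lean on. The expected step in this assay from compound 3 to compound 4 is a modest move toward a higher number, a 1.7-fold higher number from compound 3 to compound 4 (0.22 log units; within the scatter), possibly not beyond the scatter. Compound 4 is estimated at 6000 nM, between 1800 nM and 25000 nM.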

Compound 4, concentration for total growth inhibition: 39200 nM
Estimate against measurement, compound 4: 6.5-fold (0.82 log units) below; the whole stated range lies below it.
By their numbers in this assay, from the lowest: compound 3; then compound 4; then compound 2. At a limit, above all of these: compound 1.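

In this assay, among these compounds, the first single-place step is large, which shows that this position is sensitive to the group it carries: an 11-fold higher number from compound 3 to compound 4 (1.04 log units; beyond the scatter). Phenoxy and dimethylamino, on an aromatic carbon para to a large group, match in hydrogen-bond donors and acceptors, so those counts do not separate them; the groups differ in the carbon-only aromatic ring and in heavy atoms. Nothing measured here accounts for the step.

Open, going by these compounds, is where a methoxy, anilino or benzyloxy group at this carbon would fall relative to compound 3 and compound 4.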